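A few compounds are considered here, and "the series" means these few. Any claim that something is new, unique, unknown or untested is made for them only; others in the source may bear on it.

Among the compounds with values here, in a functional assay on K562 cells (Homo sapiens) for cytotoxicity, read by fluorescence, with a stated time of 72 h (on this read-out lower numbers stand for stronger inhibition and higher numbers for weaker inhibition), compound 1 (`CSc1nc(NCc2ccc(-c3ccccn3)cc2)c2[nH]nc(C(C)C)c2n1`) gives 778 nM and compound 2 (`CC(C)c1n[nH]c2c(NCc3ccc(-c4ccccn4)cc3)nc(NCC(C)(C)O)nc12`) gives 29 nM, the lower of the two numbers so far. Compound 3 (`CC(C)c1n[nH]c2c(NCc3ccc(-c4ccccn4)cc3)nc(NCCN)nc12`) departs from compound 2 by aminomethyl in place of 1-hydroxy-1-methylethyl on a saturated chain carbon bound to a nitrogen on an aromatic ring, which also reads as 2-hydroxy-2-methylpropyl to 2-aminoethyl. Within the data shown here, the only measured step is a 27-fold lower number from compound 1 to compound 2 (1.43 log units; beyond the scatter), with (2-hydroxy-2-methylpropyl)amino in place of methylsulfanyl. That step bears on the change only indirectly, as it introduced the chain now being altered. Among the measured compounds shown here, no measured step varies the chain itself, and compound 3 retains the amino link. As far as these compounds go, a large step is therefore not expected, and the direction remains open. The expected change is a 1.4-fold higher number from compound 2 to compound 3 (0.14 log units; within the scatter), none beyond the scatter. The estimate for compound 3 is 40 nM, with a range of 12 nM to 130 nM.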

Compound 3, half-maximal inhibitory concentration: 63 nM
Compound 3: middle estimate off by 1.6-fold (0.20 log units), on the low side; low and high end bracket the measured number.
By their numbers in this assay, from the lowest: compound 2; then compound 3; then compound 1.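

In this assay, aminomethyl in place of 1-hydroxy-1-methylethyl gives a 2.2-fold higher number from compound 2 to compound 3 (0.34 log units; beyond the scatter), the first measured change within the chain itself, and this modest step shows that the chain's makeup affects the read-out. Most of the earlier gain over methylsulfanyl survives with the new chain, at a 12-fold lower number from compound 1 to compound 3 (1.09 log units; beyond the scatter), so among these compounds that gain does not depend on 2-hydroxy-2-methylpropyl alone. Nothing available explains the difference between the two chains.

The change from 2-hydroxy-2-methylpropyl to 2-aminoethyl alters both the chain's branching and its hydroxyl or amine group, so the compounds shown cannot separate these contributions. A 2-hydroxyethyl or 3-aminopropyl group on the same nitrogen would help to separate them.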